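The compounds below may be only part of what the source reports. "The series", "measured", "known", "first", "only" and "open" are said of these compounds alone.

Compound 1 `CCCCn1ccc(-c2ccc(Oc3cccnc3C)cc2)c(C#N)c1=O` gives 347 nM in a functional assay on CHO cells for positive allosteric modulation of metabotropic glutamate receptor 2 (Homo sapiens), read by scintillation counting and GTPgammaS binding, with a stated time of 30 min; a lower number here means that less compound is needed, a higher number that more compound is needed for the effect.
Compound 2 `Cc1ncccc1Oc1ccc(-c2ccn(CCC(C)C)c(=O)c2C#N)cc1` gives 275 nM in this assay.
Compound 3 `CCCCn1ccc(-c2ccc(Oc3ccc(C)nc3C)cc2)c(C#N)c1=O` gives 138 nM in this assay.

Compound 2 differs from compound 1 by methyl in place of hydrogen on a saturated chain carbon bound to two saturated chain carbons, and that change gave a 1.3-fold lower number from compound 1 to compound 2 (0.10 log units; within the scatter). Compound 3 differs from compound 1 by methyl in place of hydrogen on an aromatic carbon, a change that gave a 2.5-fold lower number from compound 1 to compound 3 (0.40 log units; beyond the scatter). Within the data shown here, compound 4 `Cc1ccc(Oc2ccc(-c3ccn(CCC(C)C)c(=O)c3C#N)cc2)c(C)n1` has not yet been measured; it differs from compound 3 by methyl in place of hydrogen on a saturated chain carbon bound to two saturated chain carbons, which is the same change as the one from compound 1 to compound 2, now made on the core of compound 3. For compound 4 a step of a 1.3-fold lower number from compound 3 to compound 4 (0.10 log units; within the scatter) is expected in this assay, because the same change earlier gave a 1.3-fold lower number from compound 1 to compound 2 (0.10 log units; within the scatter), a small step within the scatter. Compound 4 is therefore estimated at 110 nM, most likely between 50 nM and 250 nM.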

Compound 4, half-maximal effective concentration: 100 nM
For compound 4 the middle estimate is 1.1-fold (0.04 log units) above the measured one; measured number inside the range.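

In this assay, methyl in place of hydrogen on the saturated chain carbon, the butyl to isopentyl change, gave a 1.4-fold lower number from compound 3 to compound 4 (0.14 log units; within the scatter) and so matched its earlier result on the other core: the same change on two cores in this assay, a 1.3-fold lower number (0.10 log units; within the scatter) from compound 1 to compound 2 and a 1.4-fold lower number (0.14 log units; within the scatter) from compound 3 to compound 4, 1.1-fold (0.04 log units) apart, within the scatter of two such steps
Methyl in place of hydrogen on an aromatic carbon also carried over, with a 2.8-fold lower number from compound 2 to compound 4 (0.44 log units; beyond the scatter) and a similar step on both cores: the same change on two cores in this assay, a 2.5-fold lower number (0.40 log units; beyond the scatter) from compound 1 to compound 3 and a 2.8-fold lower number (0.44 log units; beyond the scatter) from compound 2 to compound 4, 1.1-fold (0.04 log units) apart, within the scatter of two such steps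
Each change therefore behaved alike on the two cores tested, but two cores do not show that this holds across the series, and the butyl to isopentyl steps, being within the scatter, do not show that this change alters the number at all.

As far as these compounds go, it remains open whether a longer chain or a chain carrying an amine would carry over in the same way. The same question stands for a carboxylic acid in place of the methyl on the aromatic carbon.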